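The compounds below may be only part of what the source reports. "The series", "measured", "known", "first", "only" and "open" are said of these compounds alone.

Compound 1 `CC(C)OC(=O)c1cccc(NC(=O)c2cccc(-c3cc(C(=O)Nc4ccncc4F)ccc3CN)c2)c1` gives 7 nM in an assay on cells for inhibition of Rho-associated protein kinase 2 (Homo sapiens), read by radiometric assay and 33P incorporation, in the presence of a further agent that is not named here; a higher number here means a weaker inhibitor, a lower number a stronger inhibitor. Among the three measured compounds it holds the second highest number: compound 2 `CCCCOC(=O)c1cccc(NC(=O)c2cccc(-c3cc(C(=O)Nc4ccncc4F)ccc3CN)c2)c1` gives 27 nM, and compound 3 `NCc1ccc(C(=O)Nc2ccncc2F)cc1-c1cccc(NC(=O)c2ccc(C(=O)O)cc2)c1` gives 1 nM. Compound 4 `NCc1ccc(C(=O)Nc2ccncc2F)cc1-c1cccc(C(=O)Nc2ccccc2)c1` differs from compound 1 by hydrogen in place of isopropoxycarbonyl on an aromatic carbon. Among the compounds with values here, only one measured step touches this part of the molecule: a 3.9-fold higher number from compound 1 to compound 2 (0.59 log units; beyond the scatter), showing that the chain on the oxygen next to the carbonyl group moves the number. Within the data shown here, compound 3 carries a carboxylic acid in that region and gives a lower number, but no counted step leads to it. Removing the whole isopropoxycarbonyl group is therefore expected to raise the number modestly, a 2.9-fold higher number from compound 1 to compound 4 (0.46 log units; beyond the scatter). Compound 4 is estimated at 20 nM, within 5 nM to 80 nM.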

Compound 4, half-maximal inhibitory concentration: < 1 nM
Compound 4: a limit, no number; the forecaster's own chance of this, stated with the estimate: 2%; middle value at least 20-fold (1.30 log units) from the limit.
By their numbers in this assay, from the lowest: compound 3; then compound 1; then compound 2.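

Compound 4 gives a limit in this assay, not a number: the limit of < 1 nM in this assay, at which 1 of the 4 values shown sits. Hydrogen in place of isopropoxycarbonyl gives an at least 7.0-fold lower number from compound 1 to compound 4 (0.84 log units; beyond the scatter), and hydrogen in place of butoxycarbonyl gives an at least 27-fold lower number from compound 2 to compound 4 (1.43 log units; beyond the scatter), so on this aromatic carbon neither group is needed for a low number, and the bare phenyl outdoes both. The third step gives a number no higher from compound 3 to compound 4 (the limit leaves the size open), and its size cannot be read. As far as these compounds go, how far compound 4 lies under its limit stays open. So does whether a smaller group on that carbon, such as an amine or a carboxylic acid, would keep the number as low.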